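Amide to urea on the anilide of compound 2

This account rests on a few compounds, and the source may have more. Where it says the series, first, only, none or still open, it means among the compounds named here.

Compound 2 `CC(C)C(=O)Nc1ccc(S(=O)(=O)Oc2ccccc2C(C)C)cc1` gives 8600 nM in a functional assay on MCF7 cells (Homo sapiens) for antiproliferative activity, read by sulforhodamine B assay, with a stated time of 48 h; a higher number here means a weaker inhibitor, a lower number a stronger inhibitor. Compound 3 `CC(C)C(=O)Nc1ccc(S(=O)(=O)Oc2ccccc2I)cc1` gives 8100 nM, and the step of a 1.1-fold lower number from compound 2 to compound 3 (0.03 log units; within the scatter). Compound 1 `CCCCCC(=O)Nc1cccc(S(=O)(=O)Oc2ccccc2C(C)C)c1` gives 12000 nM; the three values lie within the scatter of one another, so compound 2 stands among them without a separable rank. Compound 4 `CCNC(=O)Nc1ccc(S(=O)(=O)Oc2ccccc2C(C)C)cc1` differs from compound 2 by ethylamino in place of isopropyl on a carbonyl carbon. Within the data shown here, the only measured step, from compound 2 to compound 3, changes a group on an aromatic carbon and not on the carbonyl carbon, so no measured step bears on this change. With nothing to point either way, compound 4 is expected to give 9000 nM in this assay, between 3000 nM and 27000 nM, a step of a 1.0-fold higher number from compound 2 to compound 4 (0.02 log units; within the scatter) estimated to stay within the scatter.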

Compound 4, half-maximal inhibitory concentration: 10000 nM
Beside the measured number, compound 4's estimate is 1.1-fold (0.05 log units) below it; measured number inside the range.
By their numbers in this assay, from the lowest: compounds 3, 2, 4 and 1 (each within the scatter of the next).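

Ethylamino in place of isopropyl is the first measured change on the carbonyl carbon, and in this assay it gives a 1.2-fold higher number from compound 2 to compound 4 (0.07 log units; within the scatter) and so no separable shift. Turning the amide into a urea here, with a hydrogen-bond donor in ethylamino where isopropyl has none, thus leaves the number within the scatter. Nothing measured on hand accounts for this result.

Going by these compounds, whether a longer chain or a morpholine on the carbonyl carbon would separate from compound 2 remains open. So does whether the urea behaves the same with the iodo group of compound 3.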